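A few compounds are considered here, and "the series" means these few. Any claim that something is new, unique, unknown or untested is made for them only; others in the source may bear on it.

Compound 1 `COC(=O)/C=C/c1cccc(N(Cc2ccc(/C=C/c3cccc(C(F)(F)F)c3)cc2)C(=O)C(C)C)c1` gives 267 nM in an assay on isolated protein with Bile acid receptor (Homo sapiens) as the target; on this read-out lower numbers stand for an effect already at smaller amounts and higher numbers for an effect only at larger amounts of compound.
Compound 2 `COC(=O)/C=C/c1cccc(N(Cc2ccc(-c3ccc(OC)cc3)cc2)C(=O)C(C)C)c1` gives 97 nM in this assay.
Compound 3 `COC(=O)/C=C/c1cccc(N(Cc2ccc(-c3c(OC)cccc3OC)cc2)C(=O)C(C)C)c1` gives 95 nM in this assay.

Compound 3 stands with the lowest number of the three, yet its gap to compound 2 lies within the scatter, a 1.0-fold lower number from compound 2 to compound 3 (0.01 log units; within the scatter), so the two cannot be ordered; only compound 1 sits clearly apart, a 2.8-fold lower number from compound 1 to compound 3 (0.45 log units; beyond the scatter). Compound 4 `COC(=O)/C=C/c1cccc(N(Cc2ccc(/C=C/c3ccccc3)cc2)C(=O)C(C)C)c1` has not yet been measured. It differs from compound 3 in one place: 2-phenylethenyl in place of 2,6-dimethoxyphenyl on an aromatic carbon. The step that bears on this is the reverse of a 2.8-fold lower number from compound 1 to compound 3 (0.45 log units; beyond the scatter), where a biaryl group took the place of a styryl group and the number fell modestly; the same direction appears in a 2.8-fold lower number from compound 1 to compound 2 (0.44 log units; beyond the scatter). Compound 4 returns to a styryl group, but without the trifluoromethyl of compound 1, so the data give no direct match. A modest rise in the number is therefore expected, a 2.1-fold higher number from compound 3 to compound 4 (0.32 log units; beyond the scatter). Compound 4 is estimated at 200 nM, in the range 90 nM to 450 nM.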

Compound 4, half-maximal effective concentration: 65 nM
The estimate for compound 4 lay 3.1-fold (0.49 log units) above the measured number; the whole stated range lies above it.
By their numbers in this assay, from the lowest: compounds 4, 3 and 2 (each within the scatter of the next); then compound 1.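

In this assay, the unsubstituted 2-phenylethenyl group cannot be separated from either biaryl group, with a 1.5-fold lower number from compound 3 to compound 4 (0.16 log units; within the scatter) and a 1.5-fold lower number from compound 2 to compound 4 (0.17 log units; within the scatter), so the ethenyl-linked group as such does not set the compounds apart at this position. The step that does exceed the scatter is the loss of trifluoromethyl, a 4.1-fold lower number from compound 1 to compound 4 (0.61 log units; beyond the scatter), which ties the higher number of compound 1 to that group and not to the 2-phenylethenyl group itself. Nothing given here accounts for this difference.

On these data alone, it remains open whether a nitrile or an amine on the same phenyl ring would follow trifluoromethyl or hydrogen. As far as these compounds go, a longer chain in place of the ethenyl link is equally open, as is whether the shift from trifluoromethyl depends on where that group sits on the ring.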